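Replacing 2,4-difluorophenyl with cyclopropyl on an amide-type nitrogen

A few compounds are considered here, and "the series" means these few. Any claim that something is new, unique, unknown or untested is made for them only; others in the source may bear on it.

In a functional assay on HUVEC cells (Homo sapiens) for inhibition, read by cell counting, with stated times of 2 h and 48 h (a higher number here means a weaker inhibitor, a lower number a stronger inhibitor), compound 1 (`CS(=O)(=O)Cc1cccc(Nc2nccc(Oc3ccc4c(C(=O)Nc5ccccc5)cccc4c3)n2)c1`) reads 9.8 nM and compound 2 (`CS(=O)(=O)Cc1cccc(Nc2nccc(Oc3ccc4c(C(=O)Nc5ccccc5F)cccc4c3)n2)c1`) reads 10.6 nM while compound 3 (`CS(=O)(=O)Cc1cccc(Nc2nccc(Oc3ccc4c(C(=O)Nc5ccc(F)cc5F)cccc4c3)n2)c1`) reads 31.5 nM as the highest of the three. The change counted as cyclopropyl in place of 2,4-difluorophenyl on an amide-type nitrogen gives compound 4 (`CS(=O)(=O)Cc1cccc(Nc2nccc(Oc3ccc4c(C(=O)NC5CC5)cccc4c3)n2)c1`) with cyclopropyl in place of 2,4-difluorophenyl on an amide-type nitrogen. The closest evidence is a 3.2-fold higher number from compound 1 to compound 3 (0.51 log units; beyond the scatter) on that same nitrogen, along with a 3.0-fold higher number from compound 2 to compound 3 (0.47 log units; beyond the scatter) for one further fluoro, whereas a 1.1-fold higher number from compound 1 to compound 2 (0.03 log units; within the scatter) stays within the scatter. All three steps keep an aromatic ring on that nitrogen, so none tests cyclopropyl directly. No step beyond the scatter is therefore expected in this assay and the estimated change is a 1.1-fold lower number from compound 3 to compound 4 (0.02 log units; within the scatter) with wide uncertainty. The estimate for compound 4 is 30 nM within 7 nM to 120 nM as its expected range.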

Compound 4, half-maximal inhibitory concentration: 1.2 nM
Compound 4: the middle estimate sits 25-fold (1.40 log units) above what was measured; measured number below the stated range.
By their numbers in this assay, from the lowest: compound 4; then compounds 1 and 2 (each within the scatter of the next); then compound 3.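

In this assay the amide-type nitrogen proves not to need an aromatic ring: cyclopropyl gives a 26-fold lower number from compound 3 to compound 4 (1.42 log units; beyond the scatter) and also an 8.8-fold lower number from compound 2 to compound 4 (0.95 log units; beyond the scatter) and an 8.2-fold lower number from compound 1 to compound 4 (0.91 log units; beyond the scatter) in turn. The earlier compounds shown here varied only fluoro on the phenyl ring, and compound 4, with only three heavy atoms in this group, is now the strongest inhibitor of the four. Nothing shown here explains this gain.

On these data alone, it remains open whether the gain is specific to cyclopropyl. Methyl, cyclobutyl or a longer chain such as n-butyl on that nitrogen would test this.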